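A few compounds are considered here, and "the series" means these few. Any claim that something is new, unique, unknown or untested is made for them only; others in the source may bear on it.

Compound 1 `O=C(O)c1cc(C2N=NN=N2)ccc1O`: 110 mg/kg in a functional assay on the whole organism for inhibition, with Rattus norvegicus as the target, read by paw edema; on this read-out higher numbers stand for an effect only at larger amounts of compound and lower numbers for an effect already at smaller amounts
Compound 3 `O=C(O)c1cc(-n2nccn2)ccc1O`: 150 mg/kg in this assay
Compound 2 `O=C(O)c1cc(-c2cc[nH]n2)ccc1O`: > 250 mg/kg in this assay, a limit of > 250 mg/kg in this assay, at which 1 of the 3 values shown sits.

Compound 3 is one of the two numbers; its distance from compound 1 is a 1.4-fold higher number from compound 1 to compound 3 (0.13 log units; within the scatter). Compound 4 `O=C(O)c1cc(-c2nccs2)ccc1O` carries 1,3-thiazol-2-yl in place of 2H-1,2,3-triazol-2-yl on an aromatic carbon. Three steps between rings at this place are known: an at least 2.2-fold higher number from compound 1 to compound 2 (0.35 log units; beyond the scatter), a 1.4-fold higher number from compound 1 to compound 3 (0.13 log units; within the scatter) and an at least 1.6-fold lower number from compound 2 to compound 3 (0.22 log units; that floor lies within the scatter). Two of them stay within the scatter, one reaches beyond it. The entering ring shares with compound 2 a five-membered aromatic ring with 2 hetero atoms. A modest rise, a 1.3-fold higher number from compound 3 to compound 4 (0.10 log units; within the scatter), is therefore expected, with a fair chance of a limit. Compound 4 is estimated at 190 mg/kg, between 90 mg/kg and 400 mg/kg.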

Compound 4, dose for half-maximal effect: > 250 mg/kg
Compound 4 ended at the assay's limit (the forecaster's own chance of this, stated with the estimate: 35%); middle value at least 1.3-fold (0.11 log units) from the limit.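

The value of compound 4 is a limit, and a second compound now sits there: the limit of > 250 mg/kg in this assay, at which 2 of the 4 values shown sit.

The change gives an at least 1.6-fold higher number from compound 3 to compound 4 (0.22 log units; that floor lies within the scatter), and an at least 2.2-fold higher number from compound 1 to compound 4 (0.35 log units; beyond the scatter). So a sulfur-containing ring now joins 1H-pyrazol-3-yl at the limit: here, both five-membered aromatic rings with 2 hetero atoms end there, while the rings of compound 1 and compound 3, with more hetero atoms, give numbers.

The step between compound 2 and compound 4 cannot be read, since both values are limits. On these data alone, whether a 1,3-thiazol-2-yl ring carrying an amine would return to a measurable number remains open.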